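This account rests on a few compounds, and the source may have more. Where it says the series, first, only, none or still open, it means among the compounds named here.

Of the compounds shown here, three built on one shared core have been tested in an assay on isolated protein for inhibition of Maltase-glucoamylase (Homo sapiens); a higher number here means a weaker inhibitor, a lower number a stronger inhibitor. Among the compounds with values here, compound 1 `C=C1CC[C@@H]2[C@](C)(CO)[C@H](O)CC[C@@]2(C)[C@@H]1/C=C/C1=C/C(=C/c2ccc(N(C)C)cc2)OC1=O` gives 70000 nM, and compound 2 `C=C1CC[C@@H]2[C@](C)(CO)[C@H](O)CC[C@@]2(C)[C@@H]1/C=C/C1=C/C(=C/c2ccco2)OC1=O` gives 100000 nM; the step of a 1.4-fold higher number from compound 1 to compound 2 (0.15 log units; within the scatter) is the only measured change at the double-bonded chain carbon bound to a double-bonded ring carbon. Compound 3 `C=C1CC[C@@H]2[C@](C)(COC(=O)c3cccnc3)[C@H](OC(=O)c3cccnc3)CC[C@@]2(C)[C@@H]1/C=C/C1=C/C(=C\C(C)=C\CCC/C=C/C)OC1=O` gives 28000 nM, the lowest of the three numbers, beyond the scatter from both compound 1 and compound 2. Compound 4 `C=C1CC[C@@H]2[C@](C)(COC(=O)c3cccnc3)[C@H](OC(=O)c3cccnc3)CC[C@@]2(C)[C@@H]1/C=C/C1=C/C(=C\c2ccccc2)OC1=O` differs from compound 3 by a group of 6 heavy atoms (6 carbon; one six-membered aromatic ring of carbon only) in place of a group of 9 heavy atoms (9 carbon; no ring), on a double-bonded chain carbon bound to a double-bonded ring carbon. Because compound 1 with 70000 nM and compound 2 with 100000 nM both carry a ring at that place and sit higher than compound 3, a modest rise is expected. The expected step is a 1.8-fold higher number from compound 3 to compound 4 (0.25 log units; within the scatter), and compound 4 is estimated at 50000 nM, within a range from 20000 nM to 150000 nM.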

Compound 4, half-maximal inhibitory concentration: 16000 nM
Compound 4: middle estimate off by 3.1-fold (0.49 log units), on the high side; the measured number lies below the stated range.
By their numbers in this assay, from the lowest: compounds 4 and 3 (each within the scatter of the next); then compounds 1 and 2 (each within the scatter of the next).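

In this assay, putting phenyl in place of the open chain of 9 carbons gives a 1.8-fold lower number from compound 3 to compound 4 (0.24 log units; within the scatter). On the double-bonded chain carbon bound to a double-bonded ring carbon, then, replacing this chain with a ring, and so removing its 2 double bonds, does not shift the number beyond the usual scatter. No measured evidence is available to explain this result. Going by these compounds, it remains open whether a carboxylic acid or an amine on the phenyl ring, or a longer saturated chain in its place, would move the number beyond the scatter.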